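This account rests on a few compounds, and the source may have more. Where it says the series, first, only, none or still open, it means among the compounds named here.

Three compounds share a core in which a quinolinone is joined through a methylamine to a thiazole that carries a coumarin. Compound 1 `O=c1cc(CNc2nc(-c3cc4cc(Br)cc(Br)c4oc3=O)cs2)c2cc(Cl)ccc2[nH]1`, compound 2 `Cc1cccc2c(CNc3nc(-c4cc5cc(Br)ccc5oc4=O)cs3)cc(=O)[nH]c12` and compound 3 `O=c1cc(CNc2nc(-c3cc4cc(Br)cc(Br)c4oc3=O)cs2)c2ccc(Cl)cc2[nH]1` were tested in a functional assay on the whole organism for inhibition, with Rattus norvegicus as the target, read by paw edema, in the formalin test, with a stated time of 4 h, at a dose of 100 mg/kg by the intraperitoneal route; on this read-out higher numbers stand for more inhibition at the one dose given (going by the name of the read-out) and lower numbers for less inhibition. In this assay compound 1 gives 29.8%, compound 2 gives 14.5%, and compound 3 gives 34.5%. Compound 3 thus has the highest number of the three, but its gap to compound 1 lies within the usual scatter, so the two cannot be told apart; only compound 2 sits clearly lower, beyond the scatter.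

Compound 4 `O=c1cc(CNc2nc(-c3cc4cc(Br)ccc4oc3=O)cs2)c2ccc(Cl)cc2[nH]1` differs from compound 3 in one place: hydrogen in place of bromo on an aromatic carbon. Going by the values given here, no measured pair shows the effect of such a change on its own, so the size of the step is uncertain. Among the compounds with values here, compound 2, the one compound carrying a single bromo, gives 14.5%, which hints at a weaker response with fewer bromo groups, although compound 2 also differs elsewhere. A modest downward step from compound 3 to compound 4, a number 10.5 percentage points lower from compound 3 to compound 4 (beyond the scatter), is expected, possibly still within the scatter. Compound 4 is estimated to give 24%, within a range from 12% to 36%.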

Compound 4, a percentage reported as inhibition, in the whole organism at one dose (the size of the read-out at that dose, not a potency): 13.3%
Compound 4: middle estimate off by 10.7 percentage points, on the high side; the range from low to high includes it.
By their numbers in this assay, from the lowest: compounds 4 and 2 (each within the scatter of the next); then compounds 1 and 3 (each within the scatter of the next).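

In this assay, replacing one bromo with hydrogen on this aromatic carbon, ortho to a fused ring and meta to the other bromo group, gives a number 21.2 percentage points lower from compound 3 to compound 4 (beyond the scatter). Going by these compounds alone, this pair is the first direct reading of the change: only this one place differs, and the step lies beyond the scatter, so what this carbon carries matters for the read-out at this dose. No measurement shown here bears on why the number falls, so the reason stays unknown.

From the compounds shown here alone, it remains open whether bromo is special here or whether another group on this carbon, such as fluoro, methoxy or an amine, would give a similar number. Also open, going by these compounds, is whether the step would keep its size if the chloro group elsewhere in the molecule were exchanged for a carboxylic acid.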